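The source may hold more compounds than are shown below. What is called first, only, known or untested is meant among the compounds shown, and "the series" means these compounds.

Compound 1 `COc1ccc2sc(NC(=O)CCCCCCNC(=O)C(O)(O)C(F)(F)F)nc2c1` gives 8900 nM. Compound 2 `O=C(CCCCCCNC(=O)C(O)(O)C(F)(F)F)Nc1ncc(-c2ccccc2)s1` gives 21000 nM. Compound 3 `COc1ccc(NC(=O)CCCCCCNC(=O)C(O)(O)C(F)(F)F)cc1` gives 51000 nM.

In an assay on isolated protein for inhibition of histone deacetylase 8 (Homo sapiens), read by chemiluminescence, with a stated time of 3 h (a higher number here means a weaker inhibitor, a lower number a stronger inhibitor), compound 2 stands second highest of the three numbers. Compound 1 is its nearest neighbour, with a lower number that lies beyond the scatter, and compound 3 is furthest, with a higher number that also lies beyond the scatter. Compound 4 `O=C(CCCCCCNC(=O)C(O)(O)C(F)(F)F)Nc1ncc(-c2ccc(Br)cc2)s1` differs from compound 2 by bromo in place of hydrogen on an aromatic carbon. Within the data shown here, no measured pair shows this change, so the account rests on compound 2 alone. The step is expected to be small, a 1.3-fold lower number from compound 2 to compound 4 (0.12 log units; within the scatter), with no clear direction beyond the scatter. Compound 4 is therefore estimated at 16000 nM in this assay, within a range from 5000 nM to 50000 nM.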

Compound 4, half-maximal inhibitory concentration: 10000 nM
Compound 4: middle estimate off by 1.6-fold (0.20 log units), on the high side, and the stated range covers the measured number.
By their numbers in this assay, from the lowest: compounds 1 and 4 (each within the scatter of the next); then compound 2; then compound 3.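

In this assay, among these compounds, the change from phenyl to 4-bromophenyl gives the first one-place comparison: a 2.1-fold lower number from compound 2 to compound 4 (0.32 log units; beyond the scatter) is a modest step that lies beyond the scatter. It shows that this carbon of the six-membered aromatic ring, para to a large group, accepts a bromo group with a lower number rather than a higher one. From the compounds shown here alone, whether a chloro group, a methoxy group or an amine at the same carbon would give a similar step remains open. So does whether the step would recur on another core. Nothing measured here accounts for the step.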